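Removing One Fluoro from a Compound at the Assay Limit

A few compounds are considered here, and "the series" means these few. Any claim that something is new, unique, unknown or untested is made for them only; others in the source may bear on it.

In a functional assay on A549 cells (Homo sapiens) for antiproliferative activity, read by MTT assay (on this read-out lower numbers stand for stronger inhibition and higher numbers for weaker inhibition), compound 1 (`Cc1nn2c(-c3nc4cc(Cl)c(F)cc4[nH]3)c(-c3ccc(F)cc3)nc2s1`) gives > 30000 nM, which is a limit of the assay and not a number. Compound 3 (`Cc1nn2c(-c3nc4cc(F)ccc4[nH]3)c(-c3ccccc3)nc2s1`) gives > 30000 nM, also a limit. Compound 1 therefore stands at the limit of > 30000 nM in this assay, at which 2 of the 3 values shown sit. Compound 2 (`Cc1nn2c(-c3nc4cc(Cl)c(F)cc4[nH]3)c(-c3ccccc3)nc2s1`) gives a true number, 16400 nM.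

Compound 4 (`Cc1nn2c(-c3nc4cc(Cl)ccc4[nH]3)c(-c3ccc(F)cc3)nc2s1`) differs from compound 1 at a single place: hydrogen in place of fluoro on an aromatic carbon. This is hydrogen in place of fluoro on an aromatic carbon, ortho to a chloro group. Among the compounds with values here, the only measured step of this kind is an at least 1.8-fold lower number from compound 1 to compound 2 (0.26 log units; that floor lies within the scatter). That step removes the other fluoro of compound 1, so it is a loose guide to this change. On that basis, a small move toward a lower number is expected, possibly none beyond the scatter. The expected step is an at least 1.5-fold lower number from compound 1 to compound 4 (0.17 log units; that floor lies within the scatter). For compound 4, the estimated value is 20000 nM, with an expected range from 9000 nM to 30000 nM.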

Compound 4, half-maximal inhibitory concentration: 10200 nM
Compound 4: middle estimate off by 2.0-fold (0.29 log units), on the high side; the measured number falls inside the stated range.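

In this assay, the fluoro ortho to a chloro group turns out to matter: replacing it with hydrogen gives an at least 2.9-fold lower number from compound 1 to compound 4 (0.46 log units; beyond the scatter). The earlier step, which removed the other fluoro, gave an at least 1.8-fold lower number from compound 1 to compound 2 (0.26 log units; that floor lies within the scatter), so only the change at this position is shown clearing the usual scatter. The true size of the new step may be larger, because compound 1 sits at a limit and not at a number: the limit of > 30000 nM in this assay, at which 2 of the 4 values shown sit.

The compounds shown leave open whether another group on this same aromatic carbon, such as a methoxy group, an amine or a nitrile, would lower the number further or raise it again. They also leave open what happens when both fluoro groups of compound 1 are replaced by hydrogen together.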